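A few compounds are considered here, and "the series" means these few. Any claim that something is new, unique, unknown or untested is made for them only; others in the source may bear on it.

Measured so far:
- Compound 1 `COc1ccc(N2C(=O)COc3ccc(-c4ccc(O)cc4)cc32)cc1`: 16400 nM
- Compound 2 `COc1cccc(N2C(=O)COc3ccc(-c4cnc5ccccc5c4)cc32)c1`: 11400 nM
- Compound 3 `COc1cccc(N2C(=O)COc3ccc(-c4ccc(O)cc4)cc32)c1`: > 40000 nM

In a functional assay on HeLa cells (Homo sapiens) for antiproliferative activity, read by MTT assay, with a stated time of 72 h (a lower number here means a stronger inhibitor, a higher number a weaker inhibitor), compound 2 gives 11400 nM and compound 1 gives 16400 nM, two values that lie within the scatter of each other. Compound 3 gives > 40000 nM, which is a limit of the assay and not a number.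

Compound 4 `O=C1COc2ccc(-c3cnc4ccccc4c3)cc2N1c1ccc(F)cc1` has not yet been measured. It differs from compound 2 in one place: 4-fluorophenyl in place of 3-methoxyphenyl on an amide-type nitrogen in a ring. In words, 4-fluorophenyl stands in place of 3-methoxyphenyl on an amide-type nitrogen in a ring.

Among the compounds with values here, only one measured step bears on this place: an at least 2.4-fold higher number from compound 1 to compound 3 (0.38 log units; beyond the scatter). That step lies beyond the scatter, and it shows that the group on this nitrogen can shift the number in this assay. Within the data shown here, it exchanges one methoxyphenyl for another, however, so it gives only a loose guide, and no measured compound carries 4-fluorophenyl. A small move towards a lower number is therefore expected in this assay, but none beyond the scatter. The expected change is a 1.4-fold lower number from compound 2 to compound 4 (0.15 log units; within the scatter). Compound 4 is estimated at 8000 nM, with an expected range of 3000 nM to 22000 nM.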

Compound 4, half-maximal inhibitory concentration: 38800 nM
Compound 4: the middle estimate sits 4.9-fold (0.69 log units) below what was measured, outside the stated range (above it).
By their numbers in this assay, from the lowest: compounds 2 and 1 (each within the scatter of the next); then compound 4. At a limit, above all of these: compound 3.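

In this assay, 4-fluorophenyl in place of 3-methoxyphenyl on the amide-type nitrogen gives a 3.4-fold higher number from compound 2 to compound 4 (0.53 log units; beyond the scatter), so the group on this nitrogen also moves the number on the core of compound 2. Within the data shown here, the only earlier step at this place, an at least 2.4-fold higher number from compound 1 to compound 3 (0.38 log units; beyond the scatter), exchanged one methoxyphenyl for another on the core of compound 1, and it ended at a limit and not a number. Among these compounds, the new step is the first at this place between two measured numbers and the first to replace the methoxy group with fluorine, and it too goes towards a higher number. Compound 3 is the compound that sits at a limit in this assay, and that limit marks how little room remains for reading any further rise: the limit of > 40000 nM in this assay, at which 1 of the 4 values shown sits.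

The step from compound 2 to compound 4 changes the substituent and its place on the phenyl ring together, so the two contributions cannot be separated. Also open, going by these compounds, is how a 3-fluorophenyl, a plain phenyl, or a phenyl carrying an amine or a carboxylic acid would read on this nitrogen.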